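One Aryl Swap, Same Expected Paw Edema Inhibition

This account rests on a few compounds, and the source may have more. Where it says the series, first, only, none or still open, it means among the compounds named here.

Compound 1, `COc1ccc(C2=NN(C(=O)CBr)C(c3c(Cl)cccc3Cl)C2)cc1OC`: 69%
Compound 2, `COc1ccc(C2CC(c3ccc(OC)c(OC)c3)=NN2C(=O)C(C)Br)c(OC)c1`: 69%

In a functional assay on the whole organism (strain albino) for inhibition, with Rattus norvegicus as the target, read by paw edema, with stated times of 30 min and 3 h, at a dose of 100 mg/kg by the oral route (a lower number here means less inhibition, a higher number more inhibition at the dose given (going by the name of the read-out)), compound 1 gives 69%, and compound 2 gives 69%. Compound 2 thus stands level with compound 1 at the digits recorded; the two values sit within the usual scatter of repeated measurements, so no difference between them can be claimed. The unmeasured compound 3, `COc1ccc(C2=NN(C(=O)C(C)Br)C(c3c(Cl)cccc3Cl)C2)cc1OC`, differs from compound 2 in one place: 2,6-dichlorophenyl in place of 2,4-dimethoxyphenyl on a saturated ring carbon. Within the data shown here, no pair of measured compounds shows this single change on its own, so its effect has not been observed directly. With the two measured values standing together, the step expected in this assay from this change is none beyond the scatter, in no particular direction. Compound 3 is therefore expected to give about 69%, estimated to lie between 55% and 80%. This estimate means a step of no change at the digits printed from compound 2 to compound 3 (within the scatter) that is expected to stay within the scatter.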

Compound 3, a percentage reported as inhibition, in the whole organism at one dose (the size of the read-out at that dose, not a potency): 60%
For compound 3 the middle estimate is 9 percentage points above the measured one, and the stated range covers the measured number.
By their numbers in this assay, from the lowest: compounds 3, 1 and 2 (each within the scatter of the next).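

In this assay the aryl group on the saturated ring carbon can now be read as a single change: 2,6-dichlorophenyl in place of 2,4-dimethoxyphenyl gives a number 9 percentage points lower from compound 2 to compound 3 (within the scatter) and so no clear effect at this position. The saturated chain carbon bound to a bromine atom and a carbonyl carbon can be read in the same way: methyl in place of hydrogen gives a number 9 percentage points lower from compound 1 to compound 3 (within the scatter) and likewise cannot be told apart from repeat-measurement noise. Nothing measured here offers an explanation for these readings. From the compounds shown here alone, whether an amine or a carboxylic acid in place of the aryl group would shift the inhibition beyond the scatter remains open. So does the effect of a longer chain, such as ethyl, in place of the methyl.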